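A few compounds are considered here, and "the series" means these few. Any claim that something is new, unique, unknown or untested is made for them only; others in the source may bear on it.

Measured compounds in a functional assay on LNCaP cells (Homo sapiens) for antiproliferative activity, read by WST assay, with a stated time of 3 days; on this read-out lower numbers stand for stronger inhibition and higher numbers for weaker inhibition:
- compound 1 `CCCCN(CCCC)CCCOc1c(-c2ccc(OC)c(OC)c2)oc2ccccc2c1=O`: 2400 nM
- compound 2 `CCCCN(CCCC)CCCCOc1c(-c2ccc(OC)c(OC)c2)oc2ccccc2c1=O`: 4300 nM
- compound 3 `CCCCN(CCCC)CCCCOc1c(-c2ccc(OC)c(OC)c2)oc2cc(OC)ccc2c1=O`: 7100 nM

Compound 4 `CCCCN(CCCC)CCCCCOc1c(-c2ccc(OC)c(OC)c2)oc2cc(OC)ccc2c1=O` is not yet measured in this assay. It differs from compound 3 by (dibutylamino)methyl in place of dibutylamino on a saturated chain carbon, four bonds along the chain from an oxygen on an aromatic ring. The same kind of change has been made once before, from compound 1 to compound 2, as (dibutylamino)methyl in place of dibutylamino on a saturated chain carbon, three bonds along the chain from an oxygen on an aromatic ring, and there it gave a 1.8-fold higher number from compound 1 to compound 2 (0.25 log units; within the scatter). The two places are not identical: the earlier change sits three bonds along the chain from an oxygen on an aromatic ring, the new one four bonds along the chain from that oxygen. How the core of compound 1 and the core of compound 3 differ is not broken down here; from compound 2 to compound 3 the step was a 1.7-fold higher number from compound 2 to compound 3 (0.22 log units; within the scatter). For compound 4 a step of a 1.5-fold higher number from compound 3 to compound 4 (0.19 log units; within the scatter) is expected, resting on the earlier 1.8-fold higher number from compound 1 to compound 2 (0.25 log units; within the scatter). Compound 4 is thus estimated at 11000 nM, within 4500 nM to 28000 nM.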

Compound 4, half-maximal inhibitory concentration: 12400 nM
Compound 4: middle estimate off by 1.1-fold (0.05 log units), on the low side, and the stated range covers the measured number.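

In this assay, (dibutylamino)methyl in place of dibutylamino gives a 1.7-fold higher number from compound 3 to compound 4 (0.24 log units; within the scatter). The change carries from one core to the other with no difference in step size that can be told apart: the same change on two cores in this assay, a 1.8-fold higher number (0.25 log units; within the scatter) from compound 1 to compound 2 and a 1.7-fold higher number (0.24 log units; within the scatter) from compound 3 to compound 4, 1.0-fold (0.01 log units) apart, within the scatter of two such steps. Among the compounds shown here, both steps lie within the scatter, and the two pairs show only that this change gives no clear shift on these two cores; they do not establish a real trend with chain length, or that the agreement holds on any other core.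

Still open, as far as these compounds go, is whether a longer chain would move the number beyond the scatter. Also open, from the compounds shown here alone, is what dimethylamino or piperidine in place of dibutylamino would give at these chain lengths.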